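The source may hold more compounds than are shown below. What is called first, only, known or untested is meant among the compounds shown, and "the series" means these compounds.

Working notes on the series. In an ADME assay on CCRF-HSB-2 cells (Homo sapiens) for cytotoxicity, with a stated time of 7 days (a higher number here means that more compound is tolerated, a lower number that less compound is tolerated), compound 3 `CCCOc1nc(N)nc2c1ncn2/C=C1/CC1(CO)CO` gives > 20000 nM, which is a limit and not a number. Compound 1 `Nc1nc(OCC(F)(F)F)c2ncn(/C=C3/CC3(CO)CO)c2n1` gives > 20000 nM, also a limit. Going by the values given here, compound 2 `CCCCCCSc1nc(N)nc2c1ncn2/C=C1/CC1(CO)CO` gives 60000 nM, the only true number so far. Compound 3 therefore stands with compound 1 at the limit of > 20000 nM in this assay, at which 2 of the 3 values shown sit.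

Compound 4 `CCCCSc1nc(N)nc2c1ncn2/C=C1/CC1(CO)CO` differs from compound 3 by butylsulfanyl in place of propoxy on an aromatic carbon. The closest measured change is a step that the limit leaves unreadable from compound 2 to compound 3, which joins the same two kinds of group. Also relevant are a step that the limit leaves unreadable from compound 1 to compound 2 and a step that the two limits leave unreadable from compound 1 to compound 3, and neither gives a size. With no readable step to carry over, the only anchor for a sulfanyl chain is compound 2 at 60000 nM. A small change in this assay is expected, with no direction fixed by the data. The expected change is a step that the limit leaves unreadable from compound 3 to compound 4. For compound 4 the estimated value is 40000 nM, with an expected range of 18000 nM to 90000 nM.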

Compound 4, half-maximal cytotoxic concentration: 89000 nM
Compound 4: middle estimate off by 2.2-fold (0.35 log units), on the low side; the measured number falls inside the stated range.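

In this assay, going by these compounds alone, hexylsulfanyl and butylsulfanyl on this aromatic carbon give the first readable step at this position, a 1.5-fold higher number from compound 2 to compound 4 (0.17 log units; within the scatter), so these two sulfanyl chains cannot be told apart here. Within the data shown here, both sulfanyl compounds carry true numbers, which gives this position a small readable pair for the first time. The steps from compound 1 and compound 3 to compound 4 cannot be read, because each starts from a limit: the limit of > 20000 nM in this assay, at which 2 of the 4 values shown sit.

Among these compounds, no compound with propoxy or 2,2,2-trifluoroethoxy at this carbon has a true number, so whether a sulfur or an oxygen link changes the result in this assay stays open. Also open, as far as these compounds go, is how a methylsulfanyl group, a longer chain such as decylsulfanyl, or an amine at this carbon would read.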